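The source may report more compounds than this note shows. Statements on the series, on what has been measured and on what is new or still open speak of the compounds shown alone.

Measured so far:
Compound 1, `COc1cc(-c2nn(-c3cccc(NC(=O)c4cccc(C(F)(F)F)c4)c3)cc2-c2ccncc2)ccc1Cl`, 560 nM
Compound 2, `O=C(Nc1cccc(-n2cc(-c3ccncc3)c(-c3ccc(Cl)c(O)c3)n2)c1)Nc1cc(C(F)(F)F)cc(C(F)(F)F)c1`, 340 nM
Compound 3, `O=C(Nc1cccc(-n2cc(-c3ccncc3)c(-c3ccc(Cl)c(O)c3)n2)c1)Nc1ccc(Cl)c(C(F)(F)F)c1`, 380 nM

Three compounds have been characterised in a functional assay on HOP-92 cells (Homo sapiens) for inhibition, read by sulforhodamine B assay, with a stated time of 48 h; on this read-out lower numbers stand for stronger inhibition and higher numbers for weaker inhibition. Compound 1 gives the largest of the three numbers, but its gap to compound 3 and its gap to compound 2 both lie within the usual scatter of repeated measurements, so the three stand together rather than in any order.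

The unmeasured compound 4, `COc1cc(-c2nn(-c3cccc(NC(=O)Nc4ccc(Cl)c(Cl)c4)c3)cc2-c2ccncc2)ccc1Cl`, differs from compound 1 in a single place: (3,4-dichlorophenyl)amino in place of 3-(trifluoromethyl)phenyl on a carbonyl carbon. Cut one bond further out, the same change reads (3-(trifluoromethyl)phenyl)carbonyl to (3,4-dichlorophenyl)carbamoyl, which brings compound 4 closer in this respect to compound 2 and compound 3.

Among the compounds with values here, no step between measured compounds is available for guidance, so the expectation for compound 4 rests on the three values alone. Given that compound 2 and compound 3 sit within the scatter of compound 1, the step from compound 1 to compound 4 in this assay is expected to be a 1.4-fold lower number from compound 1 to compound 4 (0.15 log units; within the scatter), a small change toward a lower number and not beyond the scatter. Compound 4 is therefore estimated at 400 nM, with a range from 150 nM to 1100 nM.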

Compound 4, half-maximal inhibitory concentration: 150 nM
Compound 4: middle estimate off by 2.7-fold (0.43 log units), on the high side; the range from low to high includes it.
By their numbers in this assay, from the lowest: compound 4; then compounds 2, 3 and 1 (each within the scatter of the next).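

In this assay, the step from a 3-(trifluoromethyl)phenyl to a (3,4-dichlorophenyl)amino on a carbonyl carbon gives a 3.7-fold lower number from compound 1 to compound 4 (0.57 log units; beyond the scatter), showing that this place responds to change, something the three earlier values, all within the scatter of one another, could not show. The change is not a simple one, as it adds an amino nitrogen, with its hydrogen-bond donor, and also replaces the trifluoromethyl-bearing ring with a ring bearing two chlorines, so this one step credits neither part on its own. No measurement is available that explains the difference between the two compounds.

The compounds shown leave open whether the step follows the amino nitrogen or the ring substituents, a question that a (3-(trifluoromethyl)phenyl)amino or a 3,4-dichlorophenyl on the same carbonyl carbon would address on the core of compound 1. They also leave open whether this place tolerates something other than an aromatic ring, such as a piperidine or a longer alkyl chain.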